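A few compounds are considered here, and "the series" means these few. Any claim that something is new, unique, unknown or untested is made for them only; others in the source may bear on it.

Values measured in a functional assay on DU-145 cells (Homo sapiens) for cytotoxicity, read by trypan blue exclusion, with a stated time of 96 h; on this read-out lower numbers stand for stronger inhibition and higher numbers for weaker inhibition:
- compound 1 `COc1cc(OC)c(/C=C/S(=O)(=O)Nc2ccc(OC)c(F)c2)c(OC)c1`: 200 nM
- compound 2 `COc1cc(OC)c(/C=C/S(=O)(=O)Nc2ccc(OC)c([N+](=O)[O-])c2)c(OC)c1`: 2500 nM
- compound 3 `COc1cc(OC)c(/C=C/S(=O)(=O)Nc2ccc(OC)c(N)c2)c(OC)c1`: 5 nM

Compound 3 has the lowest number of the three, with steps of a 40-fold lower number from compound 1 to compound 3 (1.60 log units; beyond the scatter) and a 500-fold lower number from compound 2 to compound 3 (2.70 log units; beyond the scatter). Compound 4 `COC(=O)C(Nc1cc(NS(=O)(=O)/C=C/c2c(OC)cc(OC)cc2OC)ccc1OC)c1ccc(Br)cc1` differs from compound 3 at its amino group: (4-bromophenyl)(methoxycarbonyl)methyl in place of hydrogen on a nitrogen on an aromatic ring, with (4-bromophenyl)(methoxycarbonyl)methyl in place of hydrogen on a nitrogen on an aromatic ring. For the measured compounds named here, no measured step shows this change. The closest evidence is the replacement of the amino group of compound 3 by other groups, and those steps, a 500-fold lower number from compound 2 to compound 3 (2.70 log units; beyond the scatter) and a 40-fold lower number from compound 1 to compound 3 (1.60 log units; beyond the scatter), were large. A moderate rise in this assay is therefore expected, though the data cannot fix its size. The expected step is a 12-fold higher number from compound 3 to compound 4 (1.08 log units; beyond the scatter). Compound 4 is estimated at 60 nM, within a range of 8 nM to 600 nM.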

Compound 4, half-maximal inhibitory concentration: 7500 nM
Estimate against measurement, compound 4: 130-fold (2.10 log units) below; measured number outside the range, above it.
By their numbers in this assay, from the lowest: compound 3; then compound 1; then compound 2; then compound 4.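

The earlier compounds shown here replaced the amino group outright, whereas compound 4 keeps the nitrogen on the aromatic ring and swaps only one hydrogen on it, and this assay shows a 1500-fold higher number from compound 3 to compound 4 (3.18 log units; beyond the scatter) for this change. Keeping that nitrogen is therefore not enough to hold the low number of compound 3 when it carries (4-bromophenyl)(methoxycarbonyl)methyl. Nothing shown here gives a measured reason for this step.

Going by these compounds, it stays open whether the whole group or only a part of it accounts for the rise. A methyl or acetyl group on that nitrogen, or a carboxylic acid in place of the methyl ester, could separate these possibilities.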